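Vinyl for propyl on the branched sugar carbon

A few compounds are considered here, and "the series" means these few. Any claim that something is new, unique, unknown or untested is made for them only; others in the source may bear on it.

Measured compounds:
compound 1, `CCC[C@@]1(O)[C@@H](CO)O[C@@H](n2ccc(=O)[nH]c2=O)[C@@H]1O`; in a functional assay on L1210 cells (Mus musculus), read by MTT assay (a higher number here means a weaker inhibitor, a lower number a stronger inhibitor), compound 1 gives > 350000 nM, which is a limit of the assay.
compound 2, `C#C[C@]1(O)[C@H](O)[C@@H](CO)O[C@H]1n1ccc(N)nc1=O`; in this assay compound 2 gives > 350000 nM, again a limit and not a number.
compound 3, `CC#C[C@@]1(O)[C@@H](CO)O[C@@H](n2ccc(N)nc2=O)[C@@H]1O`; in this assay compound 3 gives 24500 nM.

Compound 1 stands at the limit of > 350000 nM in this assay, at which 2 of the 3 values shown sit. Compound 2 sits at the same limit, and compound 3 is the only one of the three with a measured number. Nothing beyond these three values is known about the series.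

The unmeasured compound is compound 4, `C=C[C@@]1(O)[C@@H](CO)O[C@@H](n2ccc(=O)[nH]c2=O)[C@@H]1O`. Compared with compound 1 the change is vinyl in place of propyl on a saturated ring carbon. For the measured compounds named here, no step between measured compounds touches this change, so there is no measured guide to its size or direction. With compound 1 itself at the limit, the working expectation is that compound 4 stays weak in this assay, probably again reported only as a limit, and the expected step is an at least 1.1-fold lower number from compound 1 to compound 4 (0.06 log units; that floor lies within the scatter), which would be no move beyond the scatter. The estimate for compound 4 is 300000 nM, with a range from 50000 nM to 350000 nM.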

Compound 4, half-maximal inhibitory concentration: 148000 nM
Beside the measured number, compound 4's estimate is 2.0-fold (0.31 log units) above it; measured number inside the range.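

In this assay, for the compounds shown here, vinyl in place of propyl on a saturated ring carbon gives an at least 2.3-fold lower number from compound 1 to compound 4 (0.37 log units; beyond the scatter), the first step that can be read at this position and one that lies beyond the scatter. Compound 4 gives 148000 nM, so the core of compound 1 can yield a measured number once this group changes, although that number remains weak beside the other measured number in the series. Compound 1 gives > 350000 nM, a limit of the assay, so the step sets only a floor and its full size stays unknown: the limit of > 350000 nM in this assay, at which 2 of the 4 values shown sit.

Going by these compounds alone, the single step cannot separate the loss of one chain carbon from the gain of the double bond; ethyl on the same carbon would divide the two, while ethynyl or a longer chain such as butyl would show whether the change extends to other groups at this position. Within the data shown here, compound 2 and compound 3 each differ from compound 4 in more than one place, so no steps to them can be read, and the effect of vinyl on their cores remains open.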